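The source may report more compounds than this note shows. Statements on the series, on what has been measured and on what is new or still open speak of the compounds shown alone.

Compound 1, with the structure `Cc1cc(NC(=O)Nc2cccc(C(N)=O)c2)c2ccccc2n1`, is a urea built on a shared core, and in an ADME assay on HEK293 cells (Homo sapiens) for cytotoxicity, with a stated time of 72 h (a higher number here means that more compound is needed for the effect, a lower number that less compound is needed), compound 1 gives > 25000 nM, a value that is a limit of the assay rather than a number. Compound 2, `Cc1cc(NC(=O)Nc2ccc3[nH]cnc3c2)c2ccccc2n1`, gives > 25000 nM in this assay, which is likewise a limit. Compound 3, `Cc1cc(NC(=O)Nc2cnc3ccccc3c2)c2ccccc2n1`, gives > 25000 nM in this assay, again a limit. Thus compound 1 stands with the others, all resting on (the limit of > 25000 nM in this assay, at which 3 of the 3 values shown sit), and no step between measured compounds can be given.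

Compound 4 has the structure `Cc1cc(NC(=O)Nc2cccc(OC(F)(F)F)c2)c2ccccc2n1`. It differs from compound 1 by trifluoromethoxy in place of carbamoyl on an aromatic carbon. Because the three measured compounds all sit at the limit of > 25000 nM in this assay, at which 3 of the 3 values shown sit, no step beyond the usual scatter is expected in this assay, in either direction. Compound 4 is therefore expected to give about 30000 nM, in a range from 15000 nM to 60000 nM, most probably reported again as a limit. The estimated step that the limit leaves unreadable from compound 1 to compound 4 is expected to lie within the scatter.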

Compound 4, half-maximal effective concentration: 22000 nM
Beside the measured number, compound 4's estimate is 1.4-fold (0.13 log units) above it, within the range that was stated.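

At this position on the aromatic ring, compound 4 is the only one of the compounds shown that gives a readable number in this assay and does not rest on a limit. Trifluoromethoxy in place of carbamoyl gives an at least 1.1-fold lower number from compound 1 to compound 4 (0.05 log units; that floor lies within the scatter), and this figure is only a floor, so the change is seen to bring the read-out off the limit, but not how far it moves it. The true size of the step cannot be read because compound 1 carries a limit and not a number: the limit of > 25000 nM in this assay, at which 3 of the 4 values shown sit.

Going by these compounds, it remains open whether an amine, a carboxylic acid or a methoxy group at this same position would also give a number in this assay. On these data alone, it is also open whether trifluoromethoxy would do so on the ring systems that compound 2 and compound 3 carry on the urea.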